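A few compounds are considered here, and "the series" means these few. Any claim that something is new, unique, unknown or untested is made for them only; others in the source may bear on it.

Compound 1 `CCOC(=O)c1c(NC(C)c2ccccc2)[nH]c2ccc(O)cc12` is the anchor of this small set. In an assay on isolated protein for inhibition of Polyunsaturated fatty acid 5-lipoxygenase (Homo sapiens), tested at 10 uM (a higher number here means more inhibition at the concentration tested (going by the name of the read-out), a lower number less inhibition), compound 1 gives 72%, the highest of the three numbers measured. Compound 3 `CCOC(=O)c1c(NC(C)c2ccccc2)[nH]c2ccccc12` gives 51% in this assay, and compound 2 `CCOC(=O)c1c(Nc2cccnc2)[nH]c2ccc(O)cc12` gives 24%. Both measured steps move away from compound 1 and both go down: a number 21 percentage points lower from compound 1 to compound 3 (beyond the scatter) when hydrogen replaces hydroxy on an aromatic carbon, and a number 48 percentage points lower from compound 1 to compound 2 (beyond the scatter) when pyridin-3-yl replaces 1-phenylethyl on the ring nitrogen.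

Compound 4 `CC(Nc1[nH]c2ccc(O)cc2c1C#N)c1ccccc1` is not yet measured. For the measured compounds named here, it differs from compound 1 in one place: cyano in place of ethoxycarbonyl on an aromatic carbon Neither measured step touches this position, so no direct precedent exists for it; the only guidance is that every change so far from compound 1 has lowered inhibition, modestly for compound 3 and strongly for compound 2. A downward step of modest size, a number 24 percentage points lower from compound 1 to compound 4 (beyond the scatter), is therefore expected. Compound 4 is estimated at 48%, within 22% to 72%.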

Compound 4, a percentage reported as inhibition, at one concentration (the size of the read-out at that concentration, not a potency): 62%
The estimate for compound 4 lay 14 percentage points below the measured number; low and high end bracket the measured number.
By their numbers in this assay, from the lowest: compound 2; then compound 3; then compounds 4 and 1 (each within the scatter of the next).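

In this assay, putting cyano in place of ethoxycarbonyl gives a number 10 percentage points lower from compound 1 to compound 4 (within the scatter), so this is the one change from compound 1 shown here that stays inside the usual scatter. At this position, then, a group of 2 heavy atoms with a triple bond cannot be told apart from one of 5 heavy atoms with a double bond, so the full ethoxycarbonyl group is not needed to keep this level of inhibition. No measurement here explains why the two groups read so alike.

Only these two groups have been seen at this position, so a carboxylic acid, a primary amide or a longer ester such as a butyl ester could behave differently. Going by these compounds, it also remains open whether the number would stay level with cyano in place of ethoxycarbonyl alongside the changes seen in compound 2 or compound 3.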